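Swapping the Side Chain on the Amide of Compound 1

The compounds below may be only part of what the source reports. "The series", "measured", "known", "first", "only" and "open" are said of these compounds alone.

Compound 1 `Cc1ccc(CC(C)C(=O)N2CCN(c3ccc(C(F)(F)F)cc3[C@@H](N)CC(C)C)CC2)cc1C` is a ligand of the shared core measured in an assay on HEK293 cells for displacement of a labelled ligand from Melanocortin receptor 4 (Homo sapiens) (a higher number here means a weaker inhibitor, a lower number a stronger inhibitor), where compound 1 gives 240 nM. Among the three measured compounds, compound 1 sits second highest. Compound 2 `Cc1cc(Cl)ccc1CC(C)C(=O)N1CCN(c2ccc(C(F)(F)F)cc2[C@@H](N)CC(C)C)CC1` gives 38 nM in this assay, a step of a 6.3-fold lower number from compound 1 to compound 2 (0.80 log units; beyond the scatter). Compound 3 `CC(C)C[C@H](N)c1cc(C(F)(F)F)ccc1N1CCN(C(=O)COc2ccc(O)cc2)CC1` gives 4600 nM, a step of a 19-fold higher number from compound 1 to compound 3 (1.28 log units; beyond the scatter); the gap from compound 2 to compound 3 is a 120-fold higher number from compound 2 to compound 3 (2.08 log units; beyond the scatter).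

Compound 4 `CC(C)C[C@H](N)c1cc(C(F)(F)F)ccc1N1CCN(C(=O)CC(C)C(=O)c2ccc(Cl)cc2)CC1` differs from compound 1 at the carbonyl carbon: 2-((4-chlorophenyl)carbonyl)propyl in place of 1-(3,4-dimethylbenzyl)ethyl on a carbonyl carbon. Within the data shown here, two measured steps bear on this. The move from compound 1 to compound 2 shows that a chlorine on the aromatic ring can go with a lower number. The move from compound 1 to compound 3, however, shows that exchanging the whole group on the carbonyl carbon for an oxygen-containing chain gave a much higher number. Since compound 4 also exchanges the whole group, a higher number is expected for compound 4, estimated as a step of a 2.9-fold higher number from compound 1 to compound 4 (0.46 log units; beyond the scatter). Compound 4 is therefore expected to give about 700 nM, in the range 150 nM to 3000 nM.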

Compound 4, inhibition constant: 1100 nM
The estimate for compound 4 lay 1.6-fold (0.20 log units) below the measured number; measured number inside the range.
By their numbers in this assay, from the lowest: compound 2; then compound 1; then compound 4; then compound 3.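

Exchanging the whole group on the carbonyl carbon need not cost as much as compound 3 suggested: in this assay, the 2-((4-chlorophenyl)carbonyl)propyl group gives a 4.6-fold higher number from compound 1 to compound 4 (0.66 log units; beyond the scatter), a modest step, and the other direction appears in a 4.2-fold lower number from compound 3 to compound 4 (0.62 log units; beyond the scatter). A chlorine on the aromatic ring does not by itself bring a low number at this position, since two groups that both carry one lie far apart, with a 29-fold higher number from compound 2 to compound 4 (1.46 log units; beyond the scatter). No measurement shown here gives a reason for these steps.

From the compounds shown here alone, the chain carbonyl and the chlorine change together in this group, so the share of each in the step remains open. Also open, going by these compounds, is how an amine or a carboxylic acid on the chain, or a longer chain, would fare on this carbonyl carbon.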